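A Carbonyl Substituent Swap Tested on a Second Core

The source may report more compounds than this note shows. Statements on the series, on what has been measured and on what is new or still open speak of the compounds shown alone.

Of the compounds shown here, three have been measured in a functional assay on HeLa cells (Homo sapiens) for cytotoxicity, read by MTT assay, with a stated time of 24 h; on this read-out lower numbers stand for stronger inhibition and higher numbers for weaker inhibition. Compound 3 `Nc1ccc2sc(NC(=S)NC(=O)N3CCOCC3)nc2c1` gives 45300 nM, and compound 1 `Nc1ccc2sc(NC(=S)NC(=O)c3ccccc3)nc2c1` gives 70100 nM. The two differ in one place, (phenyl in place of morpholin-4-yl on a carbonyl carbon), and this change made a step of a 1.5-fold higher number from compound 3 to compound 1 (0.19 log units; within the scatter). Compound 2 `O=C(NC(=S)Nc1nc2cc([N+](=O)[O-])ccc2s1)N1CCOCC1` carries a different core, and the difference between the cores is nitro in place of amino on an aromatic carbon. In this assay compound 2 gives 54800 nM, and the step of a 1.2-fold lower number from compound 2 to compound 3 (0.08 log units; within the scatter) shows that the two cores give similar numbers here. Compound 4 `O=C(NC(=S)Nc1nc2cc([N+](=O)[O-])ccc2s1)c1ccccc1` has not yet been measured. It stands to compound 2 as compound 1 stands to compound 3: phenyl in place of morpholin-4-yl on a carbonyl carbon. The place of the change reads the same in both pairs, so this is the same change carried over to the other core. Because the earlier step of a 1.5-fold higher number from compound 3 to compound 1 (0.19 log units; within the scatter) stayed within the scatter, the step from compound 2 to compound 4 is expected to be a 1.4-fold higher number from compound 2 to compound 4 (0.14 log units; within the scatter). Compound 4 is therefore estimated at 75000 nM, with a range expected from 35000 nM to 160000 nM. Since this rests on a single earlier instance, the range is kept wide.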

Compound 4, half-maximal inhibitory concentration: 75100 nM
Compound 4: middle estimate off by 1.0-fold (0.00 log units), on the low side; the measured number falls inside the stated range.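

On the core of compound 2, phenyl in place of morpholin-4-yl on a carbonyl carbon gives, in this assay, a 1.4-fold higher number from compound 2 to compound 4 (0.14 log units; within the scatter), and this step agrees with the one seen on the other core: the same change on two cores in this assay, a 1.5-fold higher number (0.19 log units; within the scatter) from compound 3 to compound 1 and a 1.4-fold higher number (0.14 log units; within the scatter) from compound 2 to compound 4, 1.1-fold (0.05 log units) apart, within the scatter of two such steps.
Nitro in place of amino on an aromatic carbon gives a 1.1-fold higher number from compound 1 to compound 4 (0.03 log units; within the scatter), and this step reads alike whether the carbonyl carries phenyl or morpholin-4-yl: the same change on two cores in this assay, a 1.2-fold lower number (0.08 log units; within the scatter) from compound 2 to compound 3 and a 1.1-fold lower number (0.03 log units; within the scatter) from compound 4 to compound 1, 1.1-fold (0.05 log units) apart, within the scatter of two such steps.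
Within these four compounds, each change therefore carries from one core to the other without a visible difference, but every step lies within the scatter, so this agreement shows only that neither change moved the number measurably here, not that a change with a clear effect would carry over in the same way.

From the compounds shown here alone, it remains open whether another group on the carbonyl carbon, such as a piperidine ring or a longer carbon chain, would shift the number beyond the scatter. The same question stands for a carboxylic acid on the aromatic carbon in place of amino or nitro.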